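A few compounds are considered here, and "the series" means these few. Any claim that something is new, unique, unknown or untested is made for them only; others in the source may bear on it.

Measured compounds:
compound 1 `CS/C(=N\C(=O)c1ccno1)NC(=O)c1ccno1` — > 100000 nM
compound 2 `CS/C(=N\C(=O)c1ccco1)NC(=O)c1ccco1` — > 100000 nM
compound 3 `O=C(/N=C(/NC(=O)c1ccno1)[Se]Cc1ccccc1)c1ccno1` — > 100000 nM

The three measured compounds were tested in a functional assay on PC-3 cells (Homo sapiens) for cytotoxicity, read by MTT assay, with a stated time of 72 h; a lower number here means a stronger inhibitor of growth, a higher number a weaker inhibitor of growth. In this assay compound 1 gives > 100000 nM, which is a limit of the assay and not a number. Compound 2 likewise gives > 100000 nM in this assay, again a limit rather than a number. Compound 3 gives > 100000 nM in this assay, also a limit. Compound 3 differs from compound 1 by a group of 8 heavy atoms (7 carbon, 1 selenium; one six-membered aromatic ring of carbon only) in place of a group of 2 heavy atoms (1 carbon, 1 sulfur; no ring), on a carbon with a double bond to nitrogen, and the step that the two limits leave unreadable from compound 1 to compound 3 cannot be read, since both ends sit at the limit of > 100000 nM in this assay, at which 3 of the 3 values shown sit. How the core of compound 2 differs from the core of compound 1 is not broken down here.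

Compound 4 `O=C(/N=C(/NC(=O)c1ccco1)[Se]Cc1ccccc1)c1ccco1` has not yet been measured in this assay. It differs from compound 2 by a group of 8 heavy atoms (7 carbon, 1 selenium; one six-membered aromatic ring of carbon only) in place of a group of 2 heavy atoms (1 carbon, 1 sulfur; no ring), on a carbon with a double bond to nitrogen, which is the same change as that from compound 1 to compound 3, made on the same kind of carbon with the same neighbours. Because every value shown sits at the limit of > 100000 nM in this assay, at which 3 of the 3 values shown sit, there is no readable step to carry over, and the expectation for compound 4 rests only on the fact that compound 2 gives > 100000 nM and that the same change left compound 3 at a limit as well. The step that the limit leaves unreadable from compound 2 to compound 4 is therefore expected to be small or unreadable. Compound 4 is estimated at 150000 nM in this assay, with a likely range from 60000 nM to 400000 nM, and most probably it will again return only a limit.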

Compound 4, concentration for total growth inhibition: 57600 nM
Compound 4: the middle estimate sits 2.6-fold (0.42 log units) above what was measured; the whole stated range lies above it.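

In this assay, putting the group of 8 heavy atoms with its six-membered aromatic ring in place of methylsulfanyl, on a carbon with a double bond to nitrogen, gives an at least 1.7-fold lower number from compound 2 to compound 4 (0.23 log units; that floor lies within the scatter); that size is only a floor, and the true step could be larger. On the core of compound 1 the same change leaves compound 3 at > 100000 nM, which is a limit of the assay and not a number, and the step to it cannot be read. The two cores therefore show neither that the change carries over nor that it fails to: a measured value appears on only one of them, and no size stands on the other to set against that floor, with the series held almost entirely at one limit: the limit of > 100000 nM in this assay, at which 3 of the 4 values shown sit.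

The compounds shown do not separate the selenium from the six-membered aromatic ring of the entering group, so either part, or both together, could stand behind the step. They also leave open what an amine or a carboxylic acid on that ring, or a longer chain in place of methylsulfanyl, would give in this assay, and whether any core would give a readable value at both ends of the change.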